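The source may hold more compounds than are shown below. What is called first, only, known or untested is meant among the compounds shown, and "the series" means these compounds.

Measured so far in a functional assay on HepG2 cells (Homo sapiens) for cytotoxicity, read by MTT assay, with a stated time of 72 h; a higher number here means a weaker inhibitor, a lower number a stronger inhibitor:
Compound 1 `Cc1cc(=O)n(-c2ccccc2C(F)(F)F)nc1C(=O)Nc1ccc(Oc2ncnc3ccsc23)cc1` gives 9230 nM.
Compound 2 `Cc1cc(=O)n(-c2ccc(F)cc2)nc1C(=O)Nc1ccc(Oc2ncnc3ccsc23)c(F)c1` gives 470 nM.
Compound 3 `Cc1cc(=O)n(-c2ccccc2C(F)(F)F)nc1C(=O)Nc1ccc(Oc2ncnc3sccc23)cc1` reaches only a limit of > 40000 nM.

Compound 3 is thus the one whose result in this assay is a limit rather than a number, and it sits at the limit of > 40000 nM in this assay, at which 1 of the 3 values shown sits. Compound 1 and compound 3 differ only in the bicyclic group on the ether oxygen, and that exchange gives an at least 4.3-fold higher number from compound 1 to compound 3 (0.63 log units; beyond the scatter). Compound 4 `Cc1ccc(-n2nc(C(=O)Nc3ccc(Oc4ncnc5sccc45)cc3)c(C)cc2=O)cc1` differs from compound 3 by 4-methylphenyl in place of 2-(trifluoromethyl)phenyl on an aromatic nitrogen. For the measured compounds named here, no measured step bears directly on this change: the single step available, an at least 4.3-fold higher number from compound 1 to compound 3 (0.63 log units; beyond the scatter), alters the other end of the molecule and leaves the group on the aromatic nitrogen untouched. Going by the values given here, compound 2 also carries a para-substituted phenyl on that nitrogen, yet it differs from compound 3 in two further places; what compound 2 shows on its own is 470 nM, and no step can be set against it. Because compound 3 sits at the limit of > 40000 nM in this assay, at which 1 of the 3 values shown sits, the direction of any step is not even anchored to a number. With that uncertainty, compound 4 is expected to land at an estimated 25000 nM (range 3000 nM to 80000 nM), which corresponds to an expected step of an at least 1.6-fold lower number from compound 3 to compound 4 (0.20 log units; that floor lies within the scatter), with a real chance that this assay again reports only a limit.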

Compound 4, half-maximal inhibitory concentration: > 40000 nM
Compound 4: only a limit was reported (the forecaster's own chance of this, stated with the estimate: 45%); at least 1.6-fold (0.20 log units) between middle value and limit.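

In this assay, compound 3 and compound 4 both report only a limit, so no step between them can be read: the limit of > 40000 nM in this assay, at which 2 of the 4 values shown sit.

The compounds shown leave open whether 4-methylphenyl or 2-(trifluoromethyl)phenyl on the aromatic nitrogen gives the lower number in this assay.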